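Dienone series: hydroxy to sulfo on the side chain

A few compounds are considered here, and "the series" means these few. Any claim that something is new, unique, unknown or untested is made for them only; others in the source may bear on it.

Measured compounds:
compound 1, `O=C1/C(=C/c2ccc(Cl)cc2)CN(C(=O)CCSCCO)C/C1=C\c1ccc(Cl)cc1`, 660 nM
compound 2, `O=C1/C(=C/c2ccc([N+](=O)[O-])cc2)CN(C(=O)CCSCCO)C/C1=C\c1ccc([N+](=O)[O-])cc1`, 390 nM

Both compounds carry the same core and the same side chain and differ only in the aryl substituents. In a functional assay on HSC-4 cells (Homo sapiens) for cytotoxicity, read by MTT assay, with a stated time of 48 h (on this read-out higher numbers stand for lower toxicity in this test and lower numbers for higher toxicity in this test), compound 1 gives 660 nM. In this assay compound 2 gives 390 nM, the lowest of the two numbers, but its gap to compound 1 lies within the scatter, so the two cannot be ordered.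

Compound 3, `O=C1/C(=C/c2ccc([N+](=O)[O-])cc2)CN(C(=O)CCSCCS(=O)(=O)O)C/C1=C\c1ccc([N+](=O)[O-])cc1`, is not yet measured. It differs from compound 2 by sulfo in place of hydroxy on a saturated chain carbon, two bonds along the chain from a sulfur. Within the data shown here, no measured pair in this set shows the effect of such a change, so no step can be computed for it. In this assay a modest step toward a higher number is expected, with a range wide enough to include no change beyond the scatter; the estimate for compound 3 is 800 nM (range 300 nM to 2500 nM). The step this estimate means is a 2.1-fold higher number from compound 2 to compound 3 (0.31 log units; beyond the scatter).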

Compound 3, half-maximal cytotoxic concentration: 4730 nM
For compound 3 the middle estimate is 5.9-fold (0.77 log units) below the measured one; the whole stated range lies below it.
By their numbers in this assay, from the lowest: compounds 2 and 1 (each within the scatter of the next); then compound 3.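

Sulfo in place of hydroxy, on a saturated chain carbon, two bonds along the chain from a sulfur, gives in this assay a large step: a 12-fold higher number from compound 2 to compound 3 (1.08 log units; beyond the scatter) marks a clear move toward lower toxicity in this test. The earlier compounds shown here shared one side chain and so gave no reading of this position; compound 3 shows that the number in this test responds strongly to a change there, with the core and aryl substituents of compound 2 held constant. Nothing available accounts for the size of this step.

As far as these compounds go, whether a carboxylic acid, an amine or a longer chain at this position would give a similar step remains open. Also open, from the compounds shown here alone, is whether sulfo in place of hydroxy would give a step of this size on compound 1, with its different aryl substituents.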